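Clearance notes: benzyl to 4-methoxyphenyl on the shared core

A few compounds are considered here, and "the series" means these few. Any claim that something is new, unique, unknown or untested is made for them only; others in the source may bear on it.

compound 1 `O=C(CCCCCNc1c(NCc2ccccc2)c(=O)c1=O)NO` — < 4.8 uL/min
compound 2 `CC(C)(Nc1c(NCCCCCC(=O)NO)c(=O)c1=O)c1ccccc1` — < 5 uL/min

Both measured compounds were run in an ADME assay on cells (Hepatocyte, Homo sapiens) for pharmacokinetics, read by LC-MS, with a stated time of 90 min, tested at 1 uM; on this read-out lower numbers stand for slow clearance and higher numbers for fast clearance. Compound 1 returns only a limit, < 4.8 uL/min, which is not a number but the reporting edge given by the limit of < 4.8 uL/min in this assay, at which 1 of the 2 values shown sits. Compound 2 likewise returns a limit, < 5 uL/min, described by the limit of < 5 uL/min in this assay, at which 1 of the 2 values shown sits. On the numbers shown, compound 1 therefore stands at the low edge of what this assay reports, and no measured step separates it from compound 2.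

Compound 3 `COc1ccc(Nc2c(NCCCCCC(=O)NO)c(=O)c2=O)cc1` is not yet measured. It differs from compound 1 by 4-methoxyphenyl in place of benzyl on a nitrogen on an aromatic ring. Going by the values given here, no step between measured compounds exists, so nothing measured fixes the size of this change. Compound 3 is expected to remain near the limit, and the estimated step that the limit leaves unreadable from compound 1 to compound 3 in this assay is expected to be none beyond the scatter. For compound 3 the estimate in this assay is 4 uL/min, with a range from 1.5 uL/min to 10 uL/min.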

Compound 3, intrinsic clearance in a liver preparation (reported as CLH), per the amount of preparation that the assay uses: < 4.7 uL/min
Compound 3: no number, only a limit (the forecaster's own chance of this, stated with the estimate: 60%); the middle value does not contradict the limit.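

In this assay compound 3 gives < 4.7 uL/min, a limit and not a number. Going by these compounds alone, compound 1 is also a limit, so no step from compound 1 to compound 3 can be read. As far as these compounds go, whether 4-methoxyphenyl in place of benzyl alters clearance on the shared core remains open.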